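Fluoro-to-methoxy swap on the aryl of compound 1

This account rests on a few compounds, and the source may have more. Where it says the series, first, only, none or still open, it means among the compounds named here.

Going by the values given here, compound 1 `O=C(Nc1nc2ccc(F)cc2s1)c1cn(-c2ccccc2)nc1-c1ccc(F)cc1` gives 4160 nM in a functional assay on HT-29 cells (Homo sapiens) for cytotoxicity, read by MTT assay, with a stated time of 72 h (on this read-out lower numbers stand for stronger inhibition and higher numbers for weaker inhibition), and holds the lowest of the two numbers measured so far. Its nearest neighbour is compound 2 `Cc1ccc2nc(NC(=O)c3cn(-c4ccccc4)nc3-c3ccc(F)cc3)sc2c1`, which in this assay gives 22900 nM; the step from a 5.5-fold higher number from compound 1 to compound 2 (0.74 log units; beyond the scatter) is the only one recorded, and it concerns a methyl in place of fluoro on an aromatic carbon elsewhere on the shared core.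

Compound 3 `COc1ccc(-c2nn(-c3ccccc3)cc2C(=O)Nc2nc3ccc(F)cc3s2)cc1` is not yet measured. It differs from compound 1 by methoxy in place of fluoro on an aromatic carbon, that is, a 4-fluorophenyl becoming a 4-methoxyphenyl, on an aromatic carbon of a six-membered aromatic ring of carbon only, para to a large group. Among the compounds with values here, no measured step touches this position, and the one step known sits on a different aromatic carbon, so it offers only the rough indication that replacing fluoro with a larger group gave a higher number there.

With no direct comparator, a small shift toward a higher number is expected, a 1.6-fold higher number from compound 1 to compound 3 (0.19 log units; within the scatter), but the range must stay wide. Compound 3 is therefore expected to give about 6500 nM in this assay, somewhere between 2000 nM and 22000 nM.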

Compound 3, half-maximal inhibitory concentration: 5560 nM
Estimate against measurement, compound 3: 1.2-fold (0.07 log units) above; low and high end bracket the measured number.
By their numbers in this assay, from the lowest: compounds 1 and 3 (each within the scatter of the next); then compound 2.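

In this assay, the change from 4-fluorophenyl to 4-methoxyphenyl gives a 1.3-fold higher number from compound 1 to compound 3 (0.13 log units; within the scatter), so at this aromatic carbon, para to a large group, methoxy in place of fluoro produces no shift that can be told from the scatter. Going by these compounds alone, the only earlier step, a 5.5-fold higher number from compound 1 to compound 2 (0.74 log units; beyond the scatter), lies on a different aromatic carbon and concerns methyl, so its result beyond the scatter does not carry over to this position, where a group with more heavy atoms than fluoro leaves the number within the scatter of compound 1. No measurement accompanying these compounds offers an explanation for this result.

Going by these compounds, with only fluoro and methoxy seen here, it remains open whether an amine, a carboxylic acid or a longer chain such as butoxy at this carbon would move the number beyond the scatter. It is also open whether 4-methoxyphenyl would behave the same way on the methyl-bearing core of compound 2, since the two changes are not seen together in any compound shown.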